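The compounds below may be only part of what the source reports. "The series", "measured", "known", "first", "only" and "open" are said of these compounds alone.

Compound 1 `COc1cc2c(Oc3ccc(NC(=O)c4nnn(-c5ccccc5)c4C)cc3F)ccnc2cc1OCCCN1CCCC1` gives 130 nM
Compound 2 `COc1cc2c(Oc3ccc(NC(=O)c4nnn(-c5ccc(C)cc5)c4C(F)(F)F)cc3F)ccnc2cc1OCCCN1CCCC1` gives 550 nM
Compound 3 `COc1cc2c(Oc3ccc(NC(=O)c4nnn(-c5ccccc5C(F)(F)F)c4C(F)(F)F)cc3F)ccnc2cc1OCCCN1CCCC1` gives 210 nM

In a functional assay on HT-29 cells (Homo sapiens) for cytotoxicity, read by MTT assay, with a stated time of 72 h (on this read-out higher numbers stand for weaker inhibition and lower numbers for stronger inhibition), compound 2 stands at the highest of the three numbers; the nearest number belongs to compound 3, and compound 1 lies furthest away. Compound 4 `COc1cc2c(Oc3ccc(NC(=O)c4nnn(-c5ccc(C)cc5)c4C(F)(F)F)cc3F)ccnc2cc1OCCCN1CCC(C)CC1` differs from compound 2 by 4-methylpiperidin-1-yl in place of pyrrolidin-1-yl on a saturated chain carbon, three bonds along the chain from an oxygen on an aromatic ring. Among the compounds with values here, no measured step touches this part of the molecule: the only measured step, a 2.6-fold lower number from compound 2 to compound 3 (0.42 log units; beyond the scatter), changes the group on an aromatic nitrogen instead, so it offers no guide here. With nothing to lean on, the expected step in this assay is no change at the digits printed from compound 2 to compound 4 (within the scatter), meaning no change beyond the scatter. As far as these compounds go, compound 4 is therefore estimated at 550 nM, with a range from 180 nM to 1700 nM; the range is wide, as the change is untested.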

Compound 4, half-maximal inhibitory concentration: 1200 nM
Compound 4: middle estimate off by 2.2-fold (0.34 log units), on the low side, and the stated range covers the measured number.
By their numbers in this assay, from the lowest: compounds 1 and 3 (each within the scatter of the next); then compound 2; then compound 4.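

In this assay the step of a 2.2-fold higher number from compound 2 to compound 4 (0.34 log units; beyond the scatter) shows that the amine end of the chain is not a silent position, since swapping pyrrolidin-1-yl for 4-methylpiperidin-1-yl weakens inhibition modestly. The earlier compounds shown here all carry pyrrolidin-1-yl, so they could not show this. Nothing available explains the shift.

This swap enlarges the ring and adds a methyl together, and the compounds shown cannot separate the two; a plain piperidin-1-yl group would bear on that. As far as these compounds go, whether morpholin-4-yl or an open-chain dimethylamino group is tolerated also stays open.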